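This account rests on a few compounds, and the source may have more. Where it says the series, first, only, none or still open, it means among the compounds named here.

Compound 1 `CC(=O)O[C@@H]1OC(=O)[C@](O)(C(C)=O)[C@@H]1C` sits at a limit of a functional assay on HT-29 cells (Homo sapiens) for cytotoxicity, read by MTT assay (a higher number here means a weaker inhibitor, a lower number a stronger inhibitor), rather than at a number: compound 1 gives > 50000 nM. Compound 2 `CC(=O)O[C@@H]1OC(=O)[C@](OC(C)=O)(C(C)=O)[C@@H]1C` is likewise only a limit, compound 2 giving > 50000 nM. Compound 3 `CC(=O)O[C@@H]1OC(=O)[C@@H](C(C)=O)[C@@H]1C` is also a limit, compound 3 giving > 50000 nM. Hence the steps a step that the two limits leave unreadable from compound 1 to compound 2, a step that the two limits leave unreadable from compound 1 to compound 3 and a step that the two limits leave unreadable from compound 2 to compound 3 cannot be read, all three values resting on (the limit of > 50000 nM in this assay, at which 3 of the 3 values shown sit). Compound 4 `CC(=O)O[C@@H]1OC(=O)[C@@](O)(C(C)=O)[C@@H]1C` differs from compound 1 only in configuration: the two compounds have the same atoms and bonds and differ only in configuration as drawn: 1 of 3 stereo elements differ; a stereocentre at a saturated ring carbon is drawn R in compound 1 and S in compound 4. No measured step bears on this change, and none of the shown values gives a number to move from. The step that the limit leaves unreadable from compound 1 to compound 4 is therefore expected to stay within the scatter of this assay. Compound 4 is expected to give 100000 nM, between 40000 nM and 300000 nM, most likely again reported only as a limit.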

Compound 4, half-maximal inhibitory concentration: > 50000 nM
Compound 4 gave a limit, no number; the forecaster's own chance of this, stated with the estimate: 85%; the middle value is on the limit's open side.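

Compound 4 gives > 50000 nM, a limit, so no step can be read between compound 1 and compound 4: the limit of > 50000 nM in this assay, at which 4 of the 4 values shown sit.

Whether this stereocentre, or any other change among the compounds shown, affects activity in this assay stays open, with no compound yet giving a number.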